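Removing a Methyl from the Ether Side Chain

The source may hold more compounds than are shown below. What is called first, only, known or untested is meant among the compounds shown, and "the series" means these compounds.

Compound 1, `CC[C@@](C)(O)CC(=O)O[C@H](CC=C(C)C)C1=CC(=O)c2c(O)ccc(O)c2C1=O`: 12700 nM
Compound 2, `CC(C)=CC[C@@H](OC(=O)C1CCCCO1)C1=CC(=O)c2c(O)ccc(O)c2C1=O`: 24700 nM
Compound 3, `COCCO[C@H](CC=C(C)C)C1=CC(=O)c2c(O)ccc(O)c2C1=O`: 43200 nM

In a functional assay on DU-145 cells (Homo sapiens) for cytotoxicity, read by MTT assay (a higher number here means a weaker inhibitor, a lower number a stronger inhibitor), compound 3 stands highest of the three numbers; the step of a 3.4-fold higher number from compound 1 to compound 3 (0.53 log units; beyond the scatter) lies beyond the scatter, while a 1.7-fold higher number from compound 2 to compound 3 (0.24 log units; within the scatter) lies within it.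

Compound 4, `CC(C)=CC[C@@H](OCCO)C1=CC(=O)c2c(O)ccc(O)c2C1=O`, differs from compound 3 in one place: hydrogen in place of methyl on an oxygen on a saturated carbon. For the measured compounds named here, no measured step alters this oxygen's substituent; both steps leading into compound 3 exchanged a carbonyl-bearing group for the 2-methoxyethyl chain and raised the number. They give no direction for the present change, so no step beyond the scatter is expected in this assay; the expected step is a 1.1-fold lower number from compound 3 to compound 4 (0.03 log units; within the scatter). Compound 4 is estimated at 40000 nM, with a range from 15000 nM to 110000 nM.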

Compound 4, half-maximal inhibitory concentration: 9900 nM
Estimate against measurement, compound 4: 4.0-fold (0.61 log units) above, outside the stated range (below it).
By their numbers in this assay, from the lowest: compounds 4, 1, 2 and 3 (each within the scatter of the next, the first and the last beyond it).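

In this assay, for the compounds shown here, hydrogen in place of methyl on this oxygen (a 4.4-fold lower number from compound 3 to compound 4 (0.64 log units; beyond the scatter)) shows that this small change alone can move the number beyond the scatter, which no earlier step tested. The 2-hydroxyethyl chain also improves on the (oxan-2-yl)carbonyl group (a 2.5-fold lower number from compound 2 to compound 4 (0.40 log units; beyond the scatter)) and matches the (2-hydroxy-2-methylbutyl)carbonyl group within the scatter (a 1.3-fold lower number from compound 1 to compound 4 (0.11 log units; within the scatter)), so a chain without a carbonyl can hold up here. Nothing available explains the change. The compounds shown leave open whether a longer chain such as 3-hydroxypropyl would keep this gain. They also leave open how an amine or a carboxylic acid in place of the hydroxy would read.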